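The compounds below may be only part of what the source reports. "The series", "measured", "known", "first", "only" and "open" are said of these compounds alone.

Measured so far:
- compound 1 `NS(=O)(=O)c1ccc2nc(-n3nc(C(F)(F)F)cc3-c3ccc(Cl)cc3)sc2c1` gives 42%
- compound 2 `NS(=O)(=O)c1ccc2nc(-n3nc(C(F)(F)F)cc3-c3ccco3)sc2c1` gives 54%
- compound 3 `NS(=O)(=O)c1ccc2nc(-n3nc(C(F)(F)F)cc3-c3ccc4ccccc4c3)sc2c1` gives 20%

In a functional assay on the whole organism (strain Wistar albino) for inhibition, with Rattus norvegicus as the target, read by paw edema, with stated times of 30 min and 4 h, at a dose of 50 mg/kg by the oral route (on this read-out lower numbers stand for less inhibition and higher numbers for more inhibition at the one dose given (going by the name of the read-out)), compound 3 stands lowest of the three numbers. The nearest is compound 1, reached by a number 22 percentage points lower from compound 1 to compound 3 (beyond the scatter); the furthest is compound 2, reached by a number 34 percentage points lower from compound 2 to compound 3 (beyond the scatter). Between the two aryl groups that are not naphthalen-2-yl the gap is a number 12 percentage points higher from compound 1 to compound 2 (beyond the scatter).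

Compound 4 `NS(=O)(=O)c1ccc2nc(-n3nc(C(F)(F)F)cc3-c3ccc(F)cc3)sc2c1` differs from compound 3 by 4-fluorophenyl in place of naphthalen-2-yl on an aromatic carbon. Within the data shown here, the step that bears on it most directly is the one from compound 1 to compound 3, since compound 4 and compound 1 both carry a single six-membered ring with one halogen on it; the change here runs that step in reverse. The step from compound 2 to compound 3 points the same way, though furan-2-yl is a different group. Among the measured compounds shown here, no measured pair compares 4-fluorophenyl with 4-chlorophenyl, so that part of the change rests on no step at all.

An upward step beyond the scatter is therefore expected, of about the size seen between compound 1 and compound 3; the expected step is a number 20 percentage points higher from compound 3 to compound 4 (beyond the scatter). Compound 4 is estimated at 40%, with a range from 28% to 52%.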

Compound 4, a percentage reported as inhibition, in the whole organism at one dose (the size of the read-out at that dose, not a potency): 50%
Compound 4: middle estimate off by 10 percentage points, on the low side; the measured number falls inside the stated range.
By their numbers in this assay, from the lowest: compound 3; then compounds 1, 4 and 2 (each within the scatter of the next, the first and the last beyond it).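

In this assay, among these compounds, fluoro in place of chloro on the phenyl ring gives no step that can be told from the scatter (a number 8 percentage points higher from compound 1 to compound 4 (within the scatter)), so the first halogen comparison at this position shows no separable effect. Compound 4 also cannot be told from the furan-2-yl compound (a number 4 percentage points lower from compound 2 to compound 4 (within the scatter)), although compound 1 and compound 2 remain separated (a number 12 percentage points higher from compound 1 to compound 2 (beyond the scatter)), while the return from naphthalen-2-yl to a single ring with fluorine is a clear gain (a number 30 percentage points higher from compound 3 to compound 4 (beyond the scatter)), leaving compound 3 apart from the other three. Nothing available explains these differences.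

Open, as far as these compounds go, is how an amine or a short alkyl chain in this place would read. A single dose also leaves open how these numbers would rank as potencies.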